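This account rests on a few compounds, and the source may have more. Where it says the series, first, only, none or still open, it means among the compounds named here.

In a functional assay (aorta) with Rattus norvegicus as the target, in the presence of a further agent that is not named here (a lower number here means that less compound is needed, a higher number that more compound is needed for the effect), compound 1 (`COC(=O)C1=C(C)N=C(C)/C(=C(/O)OC)C1c1cccc(OCc2nonc2C)c1`) gives 640 nM and compound 2 (`COC(=O)C1=C(C)N=C(C)/C(=C(/O)OC)C1c1cccc(OCc2c(C(N)=O)no[n+]2[O-])c1`) gives 1200 nM. Compound 3 (`COC(=O)C1=C(C)N=C(C)/C(=C(/O)OC)C1c1ccccc1OCc1nonc1C`) gives 41 nM, the lowest of the three numbers, with its gaps to both others beyond the scatter. Compound 4 (`COC(=O)C1=C(C)N=C(C)/C(=C(/O)OC)C1c1ccccc1OCc1c(C(N)=O)no[n+]1[O-]`) departs from compound 3 in one place: a group of 9 heavy atoms (3 carbon, 3 nitrogen, 3 oxygen; one five-membered aromatic ring with 3 hetero atoms) in place of a group of 6 heavy atoms (3 carbon, 2 nitrogen, 1 oxygen; one five-membered aromatic ring with 3 hetero atoms), on a saturated chain carbon bound to an oxygen on an aromatic ring. Going by the values given here, the only measured precedent for this exchange, a 1.9-fold higher number from compound 1 to compound 2 (0.27 log units; within the scatter), stays within the scatter, so a small rise or no step beyond the scatter is expected in this assay. That precedent is a single pair, measured at higher numbers than compound 3 shows, so the expectation stays loose. The expected step is a 1.8-fold higher number from compound 3 to compound 4 (0.26 log units; within the scatter). The estimate for compound 4 is 75 nM, with an expected range from 25 nM to 220 nM.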

Compound 4, half-maximal effective concentration: 560 nM
Compound 4: the middle estimate sits 7.5-fold (0.87 log units) below what was measured; measured number above the stated range.
By their numbers in this assay, from the lowest: compound 3; then compounds 4, 1 and 2 (each within the scatter of the next, the first and the last beyond it).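

In this assay, this exchange on the saturated chain carbon bound to an oxygen on an aromatic ring is not neutral on every core: it gives a 14-fold higher number from compound 3 to compound 4 (1.14 log units; beyond the scatter). Its size depends on the core that carries it: the same change on two cores in this assay, a 1.9-fold higher number (0.27 log units; within the scatter) from compound 1 to compound 2 and a 14-fold higher number (1.14 log units; beyond the scatter) from compound 3 to compound 4, 7.3-fold (0.86 log units) apart, beyond the scatter of two such steps Among the compounds shown, the low number of compound 3 holds only with the 4-methyl-1,2,5-oxadiazol-3-yl group in place. Open, as far as these compounds go, is which part of the entering group carries the step, and how a nitrile, a carboxylic acid or a longer chain at this place would read in this assay.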